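Swapping the amide's aryl group: from indole to trifluoromethylstyryl

This account rests on a few compounds, and the source may have more. Where it says the series, first, only, none or still open, it means among the compounds named here.

Of the compounds shown here, three sharing one core have been tested in a functional assay on MCF7 cells (Homo sapiens) for cytotoxicity, read by MTT assay, with a stated time of 72 h; a lower number here means a stronger inhibitor, a higher number a weaker inhibitor. Compound 1 `CN1[C@@H]2c3[nH]c4ccccc4c3C[C@H]1[C@H](C#N)N1[C@@H](CNC(=O)c3ccc(Cl)cc3)c3[nH]c4ccccc4c3C[C@@H]21` gives 610 nM. Compound 2 `CN1[C@@H]2c3[nH]c4ccccc4c3C[C@H]1[C@H](C#N)N1[C@@H](CNC(=O)c3ccc4ccccc4n3)c3[nH]c4ccccc4c3C[C@@H]21` gives 150 nM, a step of a 4.1-fold lower number from compound 1 to compound 2 (0.61 log units; beyond the scatter). Compound 3 `CN1[C@@H]2c3[nH]c4ccccc4c3C[C@H]1[C@H](C#N)N1[C@@H](CNC(=O)c3cc4ccccc4[nH]3)c3[nH]c4ccccc4c3C[C@@H]21` gives 9780 nM, the highest of the three numbers and thus the weakest inhibitor here; the step is a 16-fold higher number from compound 1 to compound 3 (1.21 log units; beyond the scatter) and a 65-fold higher number from compound 2 to compound 3 (1.81 log units; beyond the scatter). Within the data shown here, both of those steps show that the 1H-indol-2-yl group on the carbonyl carbon, the only group carrying a hydrogen-bond donor, goes with much weaker inhibition than either six-membered carbon ring or the quinolin-2-yl group.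

Compound 4 `CN1[C@@H]2c3[nH]c4ccccc4c3C[C@H]1[C@H](C#N)N1[C@@H](CNC(=O)/C=C/c3cccc(C(F)(F)F)c3)c3[nH]c4ccccc4c3C[C@@H]21` differs from compound 3 in one place: 2-(3-(trifluoromethyl)phenyl)ethenyl in place of 1H-indol-2-yl on a carbonyl carbon. The entering group again carries a six-membered aromatic ring of carbon only and no hydrogen-bond donor, so the two steps away from compound 3 are the ones that bear on this change, and a drop back toward the numbers of compound 1 and compound 2 is expected. For compound 4 in this assay the estimate is 600 nM, with a range from 150 nM to 2500 nM, an expected step of a 16-fold lower number from compound 3 to compound 4 (1.21 log units; beyond the scatter).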

Compound 4, half-maximal inhibitory concentration: 110 nM
Beside the measured number, compound 4's estimate is 5.5-fold (0.74 log units) above it; measured number outside the range, below it.
By their numbers in this assay, from the lowest: compounds 4 and 2 (each within the scatter of the next); then compound 1; then compound 3.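

Compound 4 shows that the aromatic ring need not sit directly on the carbonyl carbon: with 2-(3-(trifluoromethyl)phenyl)ethenyl at this position in this assay, the step is an 89-fold lower number from compound 3 to compound 4 (1.95 log units; beyond the scatter). The new group performs on a par with quinolin-2-yl, at a 1.4-fold lower number from compound 2 to compound 4 (0.13 log units; within the scatter), and does better than 4-chlorophenyl, at a 5.5-fold lower number from compound 1 to compound 4 (0.74 log units; beyond the scatter). This position therefore accepts a group with a double bond outside aromatic rings, and among these four groups the weak number stays with 1H-indol-2-yl alone.

Nothing measured here explains why these groups differ. Going by these compounds, it also remains open whether the double bond or the trifluoromethyl group matters more, which a saturated chain in place of the double bond, or an amine or a carboxylic acid in place of trifluoromethyl, would test.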